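This account rests on a few compounds, and the source may have more. Where it says the series, first, only, none or still open, it means among the compounds named here.

Measured compounds in an assay for inhibition of sodium- and chloride-dependent glycine transporter 1 (Homo sapiens); a lower number here means a stronger inhibitor, a higher number a weaker inhibitor:
- compound 1 `COc1ccc(Sc2ccccc2N2CCN(CC(=O)O)CC2)cc1`: > 10000 nM, a limit of the assay, not a number
- compound 2 `COc1ccc(Sc2ccc(C)cc2N2CCN(CC(=O)O)C(C)C2)cc1`: 1600 nM
- compound 3 `CC1CN(c2ccccc2Sc2ccc(Cl)cc2)C(C)CN1CC(=O)O`: 360 nM

Compound 3 holds the lowest of the two numbers shown in this assay; compound 2 sits clearly higher, beyond the scatter, and compound 1 gives only a limit, as noted in the limit of > 10000 nM in this assay, at which 1 of the 3 values shown sits.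

Compound 4 `CC(=O)Nc1ccc(Sc2ccccc2N2CC(C)N(CC(=O)O)CC2C)cc1` differs from compound 3 in one place: acetamido in place of chloro on an aromatic carbon. Going by the values given here, no measured pair covers this exchange, so the size of the step is open. A modest loss is expected, possibly no more than the scatter. The estimate for compound 4 in this assay is 800 nM, within 250 nM to 3000 nM, which means an expected step of a 2.2-fold higher number from compound 3 to compound 4 (0.35 log units; beyond the scatter).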

Compound 4, half-maximal inhibitory concentration: 22000 nM
Beside the measured number, compound 4's estimate is 28-fold (1.44 log units) below it; the whole stated range lies below it.
By their numbers in this assay, from the lowest: compound 3; then compound 2; then compound 4.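

In this assay, going by these compounds alone, acetamido in place of chloro on an aromatic carbon, para to a large group, gives a 61-fold higher number from compound 3 to compound 4 (1.79 log units; beyond the scatter), the first single-place comparison. This position is therefore far from indifferent to its substituent, at least for this exchange. Compound 1 gives only a limit and cannot be ordered against compound 4: the limit of > 10000 nM in this assay, at which 1 of the 4 values shown sits.

One pair cannot show whether the loss follows the whole acetamido group or one part of it. An amino group or an acetyl group on the same carbon would separate those parts, and fluoro or bromo would test how specific chloro is.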